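Swapping one fluorinated group, with little change expected

The source may hold more compounds than are shown below. What is called first, only, known or untested is meant among the compounds shown, and "the series" means these compounds.

In a functional assay on DU-145 cells (Homo sapiens) for antiproliferative activity, read by propidium iodide staining, with a stated time of 96 h (on this read-out higher numbers stand for weaker inhibition and lower numbers for stronger inhibition), compound 1 (`CC(O)(COc1cccc(S(F)(F)(F)(F)F)c1)C(=O)Nc1ccc(S(F)(F)(F)(F)F)cc1`) gives 29600 nM and compound 2 (`CC(O)(COc1cccc(OC(F)(F)F)c1)C(=O)Nc1ccc(S(F)(F)(F)(F)F)cc1`) gives 18400 nM as a pair of numbers within the scatter of each other. Compound 3 (`CC(O)(COc1cccc(S(F)(F)(F)(F)F)c1)C(=O)Nc1ccc(C(F)(F)F)cc1`) keeps the core of compound 1 but carries trifluoromethyl on an aromatic carbon, para to a large group (a group of 4 heavy atoms (1 carbon, 3 fluorine; no ring) in place of a group of 6 heavy atoms (5 fluorine, 1 sulfur; no ring), on an aromatic carbon). For the measured compounds named here, the only measured step (a 1.6-fold lower number from compound 1 to compound 2 (0.21 log units; within the scatter)) replaced a different copy of the departing group, so it is indirect evidence that such a swap moves the number little. An estimated step (a 1.2-fold lower number from compound 1 to compound 3 (0.07 log units; within the scatter)) is therefore expected to stay within the scatter. Compound 3 is expected at 25000 nM with a range from 10000 nM to 55000 nM as the likely span.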

Compound 3, half-maximal inhibitory concentration: 21000 nM
The estimate for compound 3 lay 1.2-fold (0.08 log units) above the measured number; measured number inside the range.
By their numbers in this assay, from the lowest: compounds 2, 3 and 1 (each within the scatter of the next).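

For the compounds shown here, this is the first direct swap at this place, on an aromatic carbon para to a large group: in this assay, trifluoromethyl replacing the sulfur group with five fluorines gives a 1.4-fold lower number from compound 1 to compound 3 (0.15 log units; within the scatter). At this position, then, a group with fewer heavy atoms leaves the number within the scatter. No evidence here explains this result.

From the compounds shown here alone, whether an amine, a carboxylic acid or a longer chain at this place would also stay within the scatter remains open. So does whether any group here can produce a step beyond it.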